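Capping a Hydroxy Group with a Fluorophenyl Carbamate

The source may report more compounds than this note shows. Statements on the series, on what has been measured and on what is new or still open speak of the compounds shown alone.

In a functional assay on PANC-1 cells (Homo sapiens) for inhibition, read by MTT assay, with a stated time of 24 h, tested at 10 uM (on this read-out higher numbers stand for more inhibition at the one concentration tested (going by the name of the read-out) and lower numbers for less inhibition), the three measured compounds give the following:

Compound 1 `CC(C)=CCC1Cc2c(O)cc(=O)n(CCCO)c2CC1(C)C`: 0%
Compound 2 `CC(C)=CCC/C(C)=C/CC1Cc2c(O)cc(=O)n(CCCO)c2CC1(C)C`: 0%
Compound 3 `COc1ccc(C(=O)NCCCOc2cc(=O)n(CCCO)c3c2CC(CC=C(C)C)C(C)(C)C3)cc1`: 2.5%

Compound 2 stands level with compound 1 at the lowest point of these three numbers, and compound 3 sits only slightly above them, within the scatter. Among the measured compounds shown here, the one measured step, no change at the digits printed from compound 1 to compound 2 (within the scatter), shows that adding the 3-methylbut-2-en-1-yl chain did nothing to the read-out.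

Compound 4 `CC(C)=CCC/C(C)=C/CC1Cc2c(OC(=O)Nc3ccccc3F)cc(=O)n(CCCO)c2CC1(C)C` arises from compound 2 by (2-fluorophenyl)carbamoyl in place of hydrogen on an oxygen on an aromatic ring. For the measured compounds named here, no measured step touches this oxygen, so no direct guide exists. The nearest hint is compound 3, where the same oxygen carries a larger group and the value in this assay stays near zero. The step of a number 4 percentage points higher from compound 2 to compound 4 (within the scatter) is therefore expected to be small, within the scatter, with no clear direction. Compound 4 is estimated at 4%, in a range from 0% to 15%.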

Compound 4, a percentage reported as inhibition, at one concentration (the size of the read-out at that concentration, not a potency): 0%
Estimate against measurement, compound 4: 4 percentage points above, and the stated range covers the measured number.
By their numbers in this assay, from the lowest: compounds 1, 2, 4 and 3 (each within the scatter of the next).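

Among the compounds shown here, compound 4 is the first case here where the oxygen on the aromatic ring can be judged through a single change, with the rest of compound 2 left as it was. In this assay, replacing hydroxy with ((2-fluorophenyl)carbamoyl)oxy gives no change at the digits printed from compound 2 to compound 4 (within the scatter), so adding this group and its aromatic ring at this oxygen does not lift the read-out at the one concentration tested. Nothing available explains this result.

With so little inhibition across the set, these compounds cannot show whether any group on this oxygen can raise the read-out. Still open, on these data alone, is what a carbamate bearing a simple alkyl chain, an amine or a carboxylic acid in place of the 2-fluorophenyl ring would do here.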